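The source may report more compounds than this note shows. Statements on the series, on what has been measured and on what is new or still open speak of the compounds shown alone.

In a functional assay on CHO cells for antagonist activity at Orexin/Hypocretin receptor type 1 (Homo sapiens), read by FLIPR and calcium flux (on this read-out higher numbers stand for higher potency (the scale is a negative logarithm) and lower numbers for lower potency), compound 1 `Cc1ccc(-c2ncccn2)c(C(=O)N2CCC3(CC3)C[C@H]2CNc2ccc(Cl)cn2)c1` gives 7.6, while compound 2 `Cc1nc(C(=O)N2CC3(CC3)C[C@H]2CNc2ncc(Cl)cn2)c(-c2ccccc2)s1` gives 6.8, the lower of the two numbers shown, with a gap to compound 1 that lies beyond the usual scatter. Compound 3 `Cc1cc(C(F)(F)F)cc(NC[C@@H]2CC3(CC3)CN2C(=O)c2nc(C)sc2-c2ccccc2)n1` differs from compound 2 in a single place: 6-methyl-4-(trifluoromethyl)pyridin-2-yl in place of 5-chloropyrimidin-2-yl on an amine nitrogen. Among the measured compounds shown here, no measured pair shows this exchange, so its effect has no direct precedent here. The step of a number 0.40 log units higher from compound 2 to compound 3 (beyond the scatter) is expected to be a modest gain, just beyond the scatter. Compound 3 is therefore estimated at 7.2, within a range from 6.5 to 7.9.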

Compound 3, negative logarithm of the antagonist equilibrium constant: 7.8
Beside the measured number, compound 3's estimate is 0.60 log units below it, and the stated range covers the measured number.
By their numbers in this assay, from the lowest: compound 2; then compounds 1 and 3 (each within the scatter of the next).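

In this assay, the group on the amine nitrogen emerges as a place where potency can change: 6-methyl-4-(trifluoromethyl)pyridin-2-yl in place of 5-chloropyrimidin-2-yl gives a number 1.00 log units higher from compound 2 to compound 3 (beyond the scatter) on an otherwise unchanged structure. The exchange alters the ring's hetero atoms and adds heavy atoms at once, so this single step cannot separate those changes. Nothing measured here accounts for the gain.

From the compounds shown here alone, it remains open whether an unsubstituted phenyl ring or a carboxylic acid on the ring would preserve this potency. Also open, going by these compounds, is whether the same exchange would carry over to the core of compound 1.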